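The source may report more compounds than this note shows. Statements on the series, on what has been measured and on what is new or still open speak of the compounds shown alone.

In a functional assay on the whole organism for inhibition, with Rattus norvegicus as the target, read by paw edema, at a dose of 100 mg/kg by the oral route (a higher number here means more inhibition at the dose given (going by the name of the read-out), a lower number less inhibition), compound 1 `O=C(NCc1ccccc1)c1c(O)c2cccnc2n(-c2ccccc2)c1=O` gives 1.6%, the second highest of the three numbers measured. Compound 2 `O=C(NN1CCOCC1)c1c(O)c2cccnc2n(-c2ccccc2)c1=O` gives -8.5%, and a number 10.1 percentage points lower from compound 1 to compound 2 (beyond the scatter). Compound 3 `O=C(Nc1ccncc1)c1c(O)c2cccnc2n(-c2ccccc2)c1=O` gives 34.9%, and a number 33.3 percentage points higher from compound 1 to compound 3 (beyond the scatter). Compound 4 `O=C(NCc1ccncc1)c1c(O)c2cccnc2n(-c2ccccc2)c1=O` differs from compound 1 by pyridin-4-yl in place of phenyl on a saturated chain carbon bound to an amide-type nitrogen. Among the compounds with values here, of the measured steps, only the one to compound 3 bears on this, as it also brings a pyridin-4-yl group onto the amide side, and that step was large. Compound 4 keeps the saturated chain carbon, so a smaller rise in this assay is expected, a rise in direction because a number 33.3 percentage points higher from compound 1 to compound 3 (beyond the scatter). The expected step for compound 4 is a number 13.4 percentage points higher from compound 1 to compound 4 (beyond the scatter). Compound 4 is therefore estimated at 15%, within a range from -5% to 35%.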

Compound 4, a percentage reported as inhibition, in the whole organism at one dose (the size of the read-out at that dose, not a potency): 10%
For compound 4 the middle estimate is 5 percentage points above the measured one, within the range that was stated.
By their numbers in this assay, from the lowest: compound 2; then compounds 1 and 4 (each within the scatter of the next); then compound 3.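

In this assay pyridin-4-yl in place of phenyl on a saturated chain carbon bound to an amide-type nitrogen gives a number 8.4 percentage points higher from compound 1 to compound 4 (within the scatter) and so does not separate these two compounds. The saturated chain carbon does count: (pyridin-4-yl)methyl in place of pyridin-4-yl gives a number 24.9 percentage points lower from compound 3 to compound 4 (beyond the scatter) and in place of morpholin-4-yl gives a number 18.5 percentage points higher from compound 2 to compound 4 (beyond the scatter) on the same amide-type nitrogen. Nothing measured here says why. Going by these compounds, how a longer chain would read on that nitrogen, or pyridin-3-yl in place of pyridin-4-yl, stays open.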